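Flipping One Stereocentre in a Hydroxylated Pipecolic Acid

The compounds below may be only part of what the source reports. "The series", "measured", "known", "first", "only" and "open" are said of these compounds alone.

Compound 3 `O=C(O)[C@@H]1NC[C@@H](O)[C@@H](O)[C@@H]1O` is a trihydroxy piperidine carboxylic acid; in an assay on isolated protein for inhibition of cytosolic endo-beta-N-acetylglucosaminidase (Homo sapiens), tested at 1000 uM (on this read-out lower numbers stand for less inhibition and higher numbers for more inhibition at the one concentration tested (going by the name of the read-out)), compound 3 gives 2.1%, the lowest of the three measured numbers. Compound 1 `O=C(O)[C@H]1NCC=C[C@@H]1O` gives 60% in this assay, and compound 2 `O=C(O)[C@H]1NCC=C[C@H]1O` gives 17%. Compound 4 `O=C(O)[C@H]1NC[C@@H](O)[C@@H](O)[C@@H]1O` has not yet been measured. It differs from compound 3 as follows: the two compounds have the same atoms and bonds and differ only in configuration as drawn: 1 of 4 stereo elements differ; a stereocentre at a saturated ring carbon is drawn R in compound 3 and S in compound 4.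

Within the data shown here, the one measured step that bears on this kind of change is the move between compound 1 and compound 2, which shows a number 43 percentage points lower from compound 1 to compound 2 (beyond the scatter); it rests on (the fact that compounds 1 and 2 differ only in the configuration as drawn), showing that a single change of configuration on this ring can move the read-out strongly. Since compound 3 sits near the bottom of the scale, a step for compound 4 can hardly go lower, and the precedent suggests a change of configuration may produce a large step upward, though it could also stay within the scatter.

Compound 4 is therefore estimated to give 15% in this assay, within 0% to 50%, an expected step of a number 12.9 percentage points higher from compound 3 to compound 4 (beyond the scatter).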

Compound 4, a percentage reported as inhibition, at one concentration (the size of the read-out at that concentration, not a potency): 28%
Beside the measured number, compound 4's estimate is 13 percentage points below it; the range from low to high includes it.
By their numbers in this assay, from the lowest: compound 3; then compound 2; then compound 4; then compound 1.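

With a number 25.9 percentage points higher from compound 3 to compound 4 (beyond the scatter) in this assay, the result shows that a change of configuration also moves the number beyond the scatter in the trihydroxy series, where the earlier compounds had shown such a step only in the pair with the ring double bond. The gain can be attributed to configuration alone, since nothing enters or leaves: the fact that compounds 3 and 4 differ only in the configuration as drawn. Among these compounds, in both pairs, the compound with the differing stereocentre drawn S gives the higher number, although this rests on only two pairs and says nothing about potency, as each number comes from one concentration.

Going by these compounds, the other three stereo elements of compound 4 stay as drawn, so their contribution remains open. On these data alone, it is also open whether configuration matters as much with an amide or a phosphonic acid in place of the carboxylic acid.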